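This account rests on a few compounds, and the source may have more. Where it says the series, first, only, none or still open, it means among the compounds named here.

Measured in a functional assay on HT-22 cells (Mus musculus), read by MTT assay, with a stated time of 24 h; a higher number here means that more compound is needed for the effect, a lower number that less compound is needed:
Compound 1 `CC(C)(C)c1cc(/C=C/C=C/c2cc(O)cc(O)c2)ccc1O`: 91 nM
Compound 2 `CC(C)(C)c1cc(/C=C/C=C/c2cc(O)cc(O)c2)cc(C(C)(C)C)c1O`: 119 nM
Compound 3 `Oc1ccc(/C=C/C=C/c2cc(O)cc(O)c2)cc1`: 3310 nM

Compound 2 shares the low end of these numbers with compound 1. Tert-butyl in place of hydrogen on an aromatic carbon gives a 1.3-fold higher number from compound 1 to compound 2 (0.12 log units; within the scatter). Hydrogen in place of tert-butyl gives a far larger change, a 36-fold higher number from compound 1 to compound 3 (1.56 log units; beyond the scatter).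

Compound 4 `COc1c(C(C)(C)C)cc(/C=C/C=C/c2cc(O)cc(O)c2)cc1C(C)(C)C` differs from compound 2 by one change, (methyl in place of hydrogen on an oxygen on an aromatic ring), which turns hydroxy to methoxy. Going by the values given here, neither measured step touches that oxygen, so they show only that a single change can move this assay a little or a lot. Among the compounds with values here, with no direct precedent, a moderate rise with wide uncertainty seems the fair expectation. The expected step is a 2.5-fold higher number from compound 2 to compound 4 (0.40 log units; beyond the scatter). Compound 4 is estimated at 300 nM, with an expected range of 90 nM to 1500 nM.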

Compound 4, half-maximal effective concentration: 410 nM
Compound 4: the middle estimate sits 1.4-fold (0.14 log units) below what was measured, within the range that was stated.
By their numbers in this assay, from the lowest: compounds 1 and 2 (each within the scatter of the next); then compound 4; then compound 3.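

In this assay, methyl in place of hydrogen on the oxygen on the aromatic ring gives a 3.4-fold higher number from compound 2 to compound 4 (0.54 log units; beyond the scatter). Going by these compounds alone, this oxygen, untouched by the earlier steps, therefore matters to the number, yet compound 4 still gives a value in the same assay, so the free hydroxy is not essential to the effect. No measurement shown here accounts for this step. Still open, going by these compounds, is whether a longer chain on that oxygen, such as ethyl, would move the number further, and whether hydroxy to methoxy gives a similar step on compound 1, with its single tert-butyl.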